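The source may report more compounds than this note shows. Statements on the series, on what has been measured and on what is new or still open speak of the compounds shown alone.

The account concerns a small set of compounds tested in a functional assay on the whole organism (strain CD1) with Mus musculus as the target, with a stated time of 0.5 h; on this read-out higher numbers stand for an effect only at larger amounts of compound and lower numbers for an effect already at smaller amounts. Going by the values given here, compound 1 `CC1CC(=O)N(CC(=O)N2CCN(c3ccccc3)CC2)C1=O` gives 300 mg/kg in this assay, the highest number of the two measured so far. Compound 2 `CCC1(C)CC(=O)N(CC(=O)N2CCN(c3ccccc3C)CC2)C1=O` differs from compound 1 in several places rather than in one. In this assay, among the compounds with values here, compound 2 gives 100 mg/kg; the gap between the two numbers lies beyond the usual scatter, but no single-change step connects them. The unmeasured compound 3 `CC1CC(=O)N(CC(=O)N2CCN(c3cccc(Cl)c3Cl)CC2)C1=O` keeps the core of compound 1 and differs from it in one place only: 2,3-dichlorophenyl in place of phenyl on an amine nitrogen in a ring. Within the data shown here, no measured pair that differs in this way exists here, so the size of the step can only be estimated from the two numbers in hand. A modest step toward a lower number is expected, a 1.5-fold lower number from compound 1 to compound 3 (0.18 log units; within the scatter), though a result within the scatter would not surprise. Compound 3 is therefore estimated at 200 mg/kg, with a range from 70 mg/kg to 600 mg/kg.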

Compound 3, minimum effective dose: 100 mg/kg
For compound 3 the middle estimate is 2.0-fold (0.30 log units) above the measured one; measured number inside the range.
By their numbers in this assay, from the lowest: compounds 2 and 3 (each within the scatter of the next); then compound 1.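

In this assay, going by these compounds alone, the change on the amine nitrogen in a ring gives the first single-change reading in this set: 2,3-dichlorophenyl in place of phenyl brings a 3.0-fold lower number from compound 1 to compound 3 (0.48 log units; beyond the scatter), and this step lies beyond the usual scatter. With the core of compound 1 held fixed, this one position is thus enough to shift the read-out, something the earlier pair could not show, since its members differ in several places at once. No measurement at hand accounts for the step.

The compounds shown leave open whether both chlorine atoms are needed or a phenyl with a single chlorine would give the same step. They also leave open how a methoxy group, a nitrile or a pyridine ring would behave at this position.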